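A 2-methylphenyl swap on a tolerated compound

The source may hold more compounds than are shown below. What is called first, only, known or untested is meant among the compounds shown, and "the series" means these compounds.

In an ADME assay on MT4 cells (Homo sapiens) for cytotoxicity, read by MTT assay, with a stated time of 96 h (a higher number here means that more compound is tolerated, a lower number that less compound is tolerated), compound 1 `NS(=O)(=O)c1ccc(N2N=C(c3ccc(Oc4ccccc4)cc3)CC2c2cccc(F)c2)cc1` gives 25000 nM as its reading. Compound 2 `Cc1cccc(C2CC(c3ccccc3)=NN2c2ccc(S(N)(=O)=O)cc2)c1` gives 37000 nM and compound 3 `NS(=O)(=O)c1ccc(N2N=C(c3ccc(OCc4ccccc4)cc3)CC2c2ccccc2F)cc1` gives 39000 nM in the same test. These three numbers lie within the usual scatter of one another, so compound 1 cannot be told apart from the other two. Compound 4 `Cc1ccccc1C1CC(c2ccc(Oc3ccccc3)cc2)=NN1c1ccc(S(N)(=O)=O)cc1` awaits measurement and differs from compound 1 in one place (2-methylphenyl in place of 3-fluorophenyl on a saturated ring carbon), with 2-methylphenyl in place of 3-fluorophenyl on a saturated ring carbon. Among the compounds with values here, no measured pair shows this change, so no step beyond the scatter is expected in this assay in either direction. The estimated step of a 1.2-fold higher number from compound 1 to compound 4 (0.08 log units; within the scatter) stays within that scatter. Compound 4 is expected at 30000 nM with a range of 15000 nM to 60000 nM once measured.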

Compound 4, half-maximal cytotoxic concentration: 36000 nM
For compound 4 the middle estimate is 1.2-fold (0.08 log units) below the measured one, and the stated range covers the measured number.
By their numbers in this assay, from the lowest: compounds 1, 4, 2 and 3 (each within the scatter of the next).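

In this assay, putting 2-methylphenyl in place of 3-fluorophenyl on the saturated ring carbon gives a 1.4-fold higher number from compound 1 to compound 4 (0.16 log units; within the scatter). Within the data shown here, this is the first pair that differs in one place, and it shows that, on this compound, the two groups cannot be told apart in this test. Nothing measured here offers an explanation for this result.

On these data alone, both groups have one six-membered aromatic ring of carbon only, so it remains open whether an amine or a carboxylic acid at this position would give a step beyond the scatter. As far as these compounds go, whether the same swap behaves alike on other compounds also remains open.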